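Chlorine substitution on an amide-linked phenyl ring and cytotoxicity

The source may report more compounds than this note shows. Statements on the series, on what has been measured and on what is new or still open speak of the compounds shown alone.

Three compounds sharing one core were measured in a functional assay on A549 cells (Homo sapiens) for cytotoxicity, read by MTT assay, with a stated time of 48 h; on this read-out lower numbers stand for an effect already at smaller amounts and higher numbers for an effect only at larger amounts of compound. Compound 1 `Cc1c(O)c(=O)ccn1CC(=O)N/N=C1\C(=O)N(CC(=O)Nc2ccccc2Cl)c2ccccc21` carries a 2-chlorophenyl group on the amide-type nitrogen. In this assay compound 1 gives > 100000 nM, which is a limit of the assay rather than a number (the limit of > 100000 nM in this assay, at which 1 of the 3 values shown sits). Compound 2 `Cc1c(O)c(=O)ccn1CC(=O)N/N=C1\C(=O)N(CC(=O)Nc2ccc(Cl)cc2Cl)c2ccccc21` differs from compound 1 by chloro in place of hydrogen on an aromatic carbon; in this assay compound 2 gives 61500 nM. That change made an at least 1.6-fold lower number from compound 1 to compound 2 (0.21 log units; that floor lies within the scatter). Compound 3 `Cc1c(O)c(=O)ccn1CC(=O)N/N=C1\C(=O)N(CC(=O)Nc2cccc(Cl)c2)c2ccccc21` differs from compound 1 by 3-chlorophenyl in place of 2-chlorophenyl on an amide-type nitrogen, and in this assay compound 3 gives 28000 nM. The step from the first compound is an at least 3.5-fold lower number from compound 1 to compound 3 (0.55 log units; beyond the scatter), and from the second it is a 2.2-fold lower number from compound 2 to compound 3 (0.34 log units; beyond the scatter). Compound 3 thus holds the lowest of the two numbers measured.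

Compound 4 `Cc1c(O)c(=O)ccn1CC(=O)N/N=C1\C(=O)N(CC(=O)Nc2cc(Cl)cc(Cl)c2)c2ccccc21` is not yet measured. It differs from compound 3 by chloro in place of hydrogen on an aromatic carbon. Among the compounds with values here, this is the same kind of change as the one from compound 1 to compound 2, though in compound 2 the entering chloro sits para to a large group and in compound 4 it sits meta to a large group. The earlier step started from a limit and its floor lies within the scatter, so it offers only weak guidance. Beside the earlier at least 1.6-fold lower number from compound 1 to compound 2 (0.21 log units; that floor lies within the scatter) stands the expected step for compound 4, a 1.6-fold lower number from compound 3 to compound 4 (0.19 log units; within the scatter). This expectation rests on compound 3 giving 28000 nM and on the small size of that earlier step. Compound 4 is expected to give about 18000 nM, ranging from 7000 nM to 45000 nM.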

Compound 4, half-maximal effective concentration: 22100 nM
Compound 4: middle estimate off by 1.2-fold (0.09 log units), on the low side; low and high end bracket the measured number.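

In this assay, chloro in place of hydrogen on the 3-chlorophenyl group, meta to a chloro group, gives a 1.3-fold lower number from compound 3 to compound 4 (0.10 log units; within the scatter). Set beside the earlier case of the same change, the two read as follows: the same change on two cores in this assay, an at least 1.6-fold lower number (0.21 log units; that floor lies within the scatter) from compound 1 to compound 2 and a 1.3-fold lower number (0.10 log units; within the scatter) from compound 3 to compound 4; the limit leaves it open whether they differ Neither case therefore shows a step beyond the scatter, but the first is only a floor, so this pair shows neither that the change carries over with the same size nor that it has no effect on either core.

The 3,5-dichlorophenyl group also compares with the other aryl groups on the amide-type nitrogen, where more than the one chloro differs. Against the 2,4-dichlorophenyl group the result is a 2.8-fold lower number from compound 2 to compound 4 (0.44 log units; beyond the scatter). Against the 2-chlorophenyl group it is an at least 4.5-fold lower number from compound 1 to compound 4 (0.65 log units; beyond the scatter). Compound 1 gives > 100000 nM, which is a limit of the assay and not a number, so this last step is a floor as well.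

The compounds shown leave open how far the numbers follow the places of the chloro groups rather than their count. They also leave open how a fluoro, methoxy or amine group on this phenyl ring would read in this assay.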